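The source may report more compounds than this note shows. Statements on the series, on what has been measured and on what is new or still open speak of the compounds shown alone.

Compound 1 `CCCCNc1nc(N)nc2c1ncn2/C=C1/CC1(CO)CO` is the starting point. In an ADME assay on BCBL1 cells (Homo sapiens) for cytotoxicity, with a stated time of 7 days (a lower number here means that less compound is tolerated, a higher number that more compound is tolerated), compound 1 gives > 20000 nM, which is a limit of the assay rather than a number. Within the data shown here, the one other measured compound, compound 2 `COCCOc1nc(N)nc2c1ncn2/C=C1/CC1(CO)CO`, in this assay gives > 20000 nM, again a limit. Both values therefore sit at the limit of > 20000 nM in this assay, at which 2 of the 2 values shown sit. Among the measured compounds shown here, the only measured step, the one a step that the two limits leave unreadable from compound 1 to compound 2, has no readable size, so it gives no guide to how far a change at this position moves the read-out. Compound 3 `C=CCOc1nc(N)nc2c1ncn2/C=C1/CC1(CO)CO` differs from compound 1 in one place: allyloxy in place of butylamino on an aromatic carbon. For the measured compounds named here, no measured step bears on this change, and with compound 1 itself known only as a limit, there is no basis to expect a step beyond the scatter in either direction. The expected step that the limit leaves unreadable from compound 1 to compound 3 therefore stays within the scatter. Compound 3 is expected to give about 30000 nM in this assay, within a range of 15000 nM to 80000 nM. That value would most likely again come back as a limit.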

Compound 3, half-maximal cytotoxic concentration: > 20000 nM
Compound 3 gave a limit, no number (the forecaster's own chance of this, stated with the estimate: 85%); the middle value does not contradict the limit.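

Compound 1, compound 2 and compound 3 all come back as limits in this assay, so no step among them can be read, and all three sit at one value: the limit of > 20000 nM in this assay, at which 3 of the 3 values shown sit.

The compounds shown leave open what concentration of each one the cells actually tolerate, and whether changing the group on this aromatic carbon moves that concentration at all.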